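Carbamoyl for ester oxygen at the saturated ring carbon

The compounds below may be only part of what the source reports. "The series", "measured", "known", "first", "only" and "open" are said of these compounds alone.

Compound 2 `Cc1nn(-c2ncnc3nc[nH]c23)c2c1C(OC(=O)c1ccc(F)cc1)CC(=O)N2` gives 4 nM in a functional assay on HEK293 cells for agonist activity at G-protein coupled receptor 39 (Homo sapiens), read by scintillation proximity assay and inositol phosphate accumulation, with a stated time of 75 min, in the presence of a further agent that is not named here (on this read-out lower numbers stand for an effect already at smaller amounts and higher numbers for an effect only at larger amounts of compound), level with compound 1 `Cc1nn(-c2ncnc3nc[nH]c23)c2c1C(OCc1ccc(C#N)cc1)CC(=O)N2`, which gives 4 nM. Compound 3 `Cc1nn(-c2ncnc3nc[nH]c23)c2c1C(C(=O)N(C)c1ccccc1)CC(=O)N2` carries methyl(phenyl)carbamoyl in place of ((4-fluorophenyl)carbonyl)oxy on a saturated ring carbon. Going by the values given here, the one measured step, no change at the digits printed from compound 1 to compound 2 (within the scatter), also exchanged the group on this carbon and did not move the read-out beyond the scatter; it bears on the present change only in part, since here the linking oxygen leaves as well and a carbamoyl enters. The expected step of a 1.3-fold higher number from compound 2 to compound 3 (0.10 log units; within the scatter) is therefore none beyond the scatter. Compound 3 is estimated at 5 nM, within 1.5 nM to 20 nM.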

Compound 3, half-maximal effective concentration: 32 nM
Estimate against measurement, compound 3: 6.4-fold (0.81 log units) below; the measured number lies above the stated range.
By their numbers in this assay, from the lowest: compounds 1 and 2 (each within the scatter of the next); then compound 3.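

In this assay the saturated ring carbon does not accept every group alike: methyl(phenyl)carbamoyl brings an 8.0-fold higher number from compound 2 to compound 3 (0.90 log units; beyond the scatter) and an 8.0-fold higher number from compound 1 to compound 3 (0.90 log units; beyond the scatter) while the two oxygen-linked groups stood level. That change removes the linking oxygen and enters a carbamoyl in one step, so the compounds shown cannot separate the two. No measurement here accounts for the rise.

From the compounds shown here alone, whether the methyl on the carbamoyl nitrogen matters remains open. So does how a plain phenylcarbamoyl, a benzylcarbamoyl or a carboxylic acid on this carbon would read.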